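From Aryl Sulfone to Spirocyclic Sulfonamide on a Shared Core

The compounds below may be only part of what the source reports. "The series", "measured", "known", "first", "only" and "open" are said of these compounds alone.

Of the compounds shown here, two built on a shared core have been measured in an assay on isolated protein for inhibition of Nicotinamide phosphoribosyltransferase (Homo sapiens), read by mass spectrometry, with stated times of 15 min and 30 min; on this read-out lower numbers stand for stronger inhibition and higher numbers for weaker inhibition. Compound 1 `O=C(NCc1ccc(S(=O)(=O)c2cccc(C(F)(F)F)c2)cc1)N1Cc2ccncc2C1` gives 8 nM in this assay. Compound 2 `O=C(NCc1ccc(S(=O)(=O)c2cncc(C(F)(F)F)c2)cc1)N1Cc2ccncc2C1` gives 15 nM in this assay, and of the two numbers shown it is the highest, with compound 1 nearest: a 1.9-fold higher number from compound 1 to compound 2 (0.27 log units; within the scatter). Compound 3 `O=C(NCc1ccc(S(=O)(=O)N2CC3(CCOCC3)C2)cc1)N1Cc2ccncc2C1` has not yet been measured. Its difference from compound 2 is a group of 9 heavy atoms (7 carbon, 1 nitrogen, 1 oxygen; one four-membered non-aromatic ring with 1 hetero atom, one six-membered non-aromatic ring with 1 hetero atom) in place of a group of 10 heavy atoms (6 carbon, 1 nitrogen, 3 fluorine; one six-membered aromatic ring with 1 hetero atom), on a sulfonyl sulfur.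

Among the compounds with values here, only one measured step bears on the position on the sulfonyl sulfur, a 1.9-fold higher number from compound 1 to compound 2 (0.27 log units; within the scatter), and it swapped one six-membered aromatic ring for another of the same kind. Within the data shown here, the change toward compound 3 is of a different sort, since the aromatic ring leaves altogether and a nitrogen-linked spirocyclic group enters; no measured step covers such an exchange, so any expectation carries wide uncertainty. Given that the nearest precedent in compound 2 is 15 nM, the expected step is toward a higher number, a 4.0-fold higher number from compound 2 to compound 3 (0.60 log units; beyond the scatter), most likely beyond the scatter. Compound 3 is therefore estimated at 60 nM, within a range from 12 nM to 400 nM.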

Compound 3, half-maximal inhibitory concentration: 20 nM
For compound 3 the middle estimate is 3.0-fold (0.48 log units) above the measured one; measured number inside the range.
By their numbers in this assay, from the lowest: compounds 1, 2 and 3 (each within the scatter of the next, the first and the last beyond it).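

In this assay, within the data shown here, an aromatic ring on the sulfonyl sulfur turns out not to be needed to stay in the range of the earlier compounds: the nitrogen-linked spirocyclic group in place of 5-(trifluoromethyl)pyridin-3-yl gives a 1.3-fold higher number from compound 2 to compound 3 (0.12 log units; within the scatter), so this much larger change of type leaves the number within reach of the pyridine compound. Set against the 3-(trifluoromethyl)phenyl group, the same spirocyclic group gives a 2.5-fold higher number from compound 1 to compound 3 (0.40 log units; beyond the scatter), a modest step and the only one at this position that lies beyond the scatter. No measurement at hand accounts for either step.

With a single non-aromatic group on the sulfonyl sulfur, the compounds shown leave open whether the four-membered ring, the six-membered ring with its oxygen, or the link through nitrogen carries the result. They also leave open how simpler groups on this sulfur, such as a piperidine, a morpholine or a dimethylamino group, would read in this assay, and whether the spirocyclic group would read the same on a different core.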